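Compound 4: chloro replaced by hydrogen, expectation before measurement

The compounds below may be only part of what the source reports. "The series", "measured", "known", "first", "only" and "open" are said of these compounds alone.

Three members of the series have a number in a functional assay on ileum (strain Hartley) for agonist activity at 5-hydroxytryptamine receptor 3A (Cavia porcellus); on this read-out lower numbers stand for lower potency and higher numbers for higher potency (the scale is a negative logarithm). Compound 1 `COc1cc(Cl)cc2nc(N3CCN(C)CC3)oc12` gives 6.16 and stands lowest of the three. Compound 2 `Cc1cc(Cl)cc2nc(N3CCN(C)CC3)oc12` gives 6.7. Compound 3 `CN1CCN(c2nc3cc(Cl)cc(Cl)c3o2)CC1` gives 6.51. Both measured steps away from compound 1 point upward, as a number 0.54 log units higher from compound 1 to compound 2 (beyond the scatter) and a number 0.35 log units higher from compound 1 to compound 3 (beyond the scatter). Between the two higher members, a number 0.19 log units lower from compound 2 to compound 3 (within the scatter).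

Compound 4 `COc1cccc2nc(N3CCN(C)CC3)oc12` departs from compound 1 at a different place: hydrogen in place of chloro on an aromatic carbon. None of the three measured steps touches this position; each of them alters only the methoxy group, which compound 4 retains. The measured steps therefore offer no direct guide to the size or direction of this change, and the expectation rests on a wide range rather than on a precedent within the series. In this assay compound 4 is expected to come out near 5.7, with a range from 5 to 6.4. The expected step is a number 0.46 log units lower from compound 1 to compound 4 (beyond the scatter), a modest loss that is uncertain in both size and sign.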

Compound 4, negative logarithm of the half-maximal effective concentration: < 4
Compound 4 ended at the assay's limit; the forecaster's own chance of this, stated with the estimate: 5%; middle value at least 1.70 log units away from the limit.
By their numbers in this assay, from the lowest: compound 1; then compounds 3 and 2 (each within the scatter of the next). At a limit, below all of these: compound 4.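

In this assay, among the compounds shown here, replacing chloro with hydrogen on the aromatic carbon para to a fused ring gives a number at least 2.16 log units lower from compound 1 to compound 4 (beyond the scatter), a larger change than any step among the earlier compounds, each of which altered only the methoxy group. For the compounds shown here, this shows that, with methoxy retained, the response in this assay depends strongly on the chloro group at this place, a dependence the earlier compounds could not reveal. Compound 4 gives < 4, which is a limit of the assay and not a number: the limit of < 4 in this assay, at which 1 of the 4 values shown sits.

On these data alone, it remains open whether a bromo or trifluoromethyl group on this carbon would retain the response seen with chloro, or whether an amine there would lose it. Also open, as far as these compounds go, is whether the same replacement would cost as much in compound 2 or compound 3, where methyl or a second chloro stands in place of methoxy.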